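This account rests on a few compounds, and the source may have more. Where it says the series, first, only, none or still open, it means among the compounds named here.

Measured compounds in a functional assay on A549 cells (Homo sapiens) for inhibition, read by XTT assay, with a stated time of 48 h; a lower number here means a stronger inhibitor, a higher number a weaker inhibitor:
- compound 1, `C=C(C(=O)c1ccc(OC)cc1)C(OC(C)=O)c1ccc([N+](=O)[O-])cc1`: 21300 nM
- compound 2, `C=C(C(=O)c1ccc(OC)cc1)C(OC(=O)c1ccccc1)C1CCCCC1`: 62100 nM
- compound 3, `C=C(C(=O)c1ccc(OC)cc1)C(OC(=O)c1ccccc1)c1ccc([N+](=O)[O-])cc1`: 66600 nM

All three share one core and differ at the ester and at the group on the saturated chain carbon. Compound 3 gives the highest number of the three in this assay, yet its gap to compound 2 is within the scatter, so the two cannot be told apart; only compound 1 lies clearly lower, as a 3.1-fold higher number from compound 1 to compound 3 (0.50 log units; beyond the scatter) shows.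

Compound 4, `C=C(C(=O)c1ccc(OC)cc1)C(OC(=O)c1ccccc1)c1ccc([N+](=O)[O-])cc1[N+](=O)[O-]`, differs from compound 3 by nitro in place of hydrogen on an aromatic carbon. Within the data shown here, no measured step adds a nitro group to an aromatic ring, so the guide is indirect. The nearest comparison is a 1.1-fold higher number from compound 2 to compound 3 (0.03 log units; within the scatter), where the whole group on that chain carbon was exchanged without a change beyond the scatter. With so little movement at this site, the expectation for compound 4 is no step beyond the scatter, a 1.1-fold lower number from compound 3 to compound 4 (0.05 log units; within the scatter). Compound 4 is therefore estimated at 60000 nM, with a range from 25000 nM to 150000 nM.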

Compound 4, half-maximal inhibitory concentration: 13000 nM
Compound 4: the middle estimate sits 4.6-fold (0.66 log units) above what was measured; measured number outside the range, below it.
By their numbers in this assay, from the lowest: compounds 4 and 1 (each within the scatter of the next); then compounds 2 and 3 (each within the scatter of the next).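

Nitro in place of hydrogen on an aromatic carbon, ortho to a large group and meta to a nitro group, gives a 5.1-fold lower number from compound 3 to compound 4 (0.71 log units; beyond the scatter) in this assay. The earlier comparison at this part of the molecule, a 1.1-fold higher number from compound 2 to compound 3 (0.03 log units; within the scatter), showed no change beyond the scatter even though a whole group was exchanged, whereas this small addition to the aromatic ring does move the number beyond the scatter, so the site is not insensitive to change. Nothing available here explains why the added nitro lowers the number.

From the compounds shown here alone, whether an amine or a chlorine atom on the same aromatic carbon would lower the number too remains open. So does whether this added nitro would give a similar step with methyl in place of phenyl on the ester carbonyl carbon.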